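Cyclopentylamino in place of dimethylanilino on the quinone core

The source may report more compounds than this note shows. Statements on the series, on what has been measured and on what is new or still open speak of the compounds shown alone.

Measured compounds:
compound 1 `Cc1ccc(NC2=CC(=O)c3nc4n(c3C2=O)[C@H]2OC[C@@H](O)[C@H]2OC4)cc1C`: 860 nM
compound 2 `O=C1C(NC2CC2)=CC(=O)c2c1nc1n2[C@H]2OC[C@@H](O)[C@H]2OC1`: > 4000 nM
compound 3 `COc1ccccc1NC1=CC(=O)c2c(nc3n2[C@H]2OC[C@@H](O)[C@H]2OC3)C1=O`: 1670 nM

In a functional assay on MGC-803 cells (Homo sapiens) for inhibition, read by sulforhodamine B assay (on this read-out higher numbers stand for weaker inhibition and lower numbers for stronger inhibition), compound 1 gives 860 nM. Compound 3 gives 1670 nM, a gap within the usual scatter, so compound 1 and compound 3 cannot be told apart on these numbers. For compound 2 the assay reports only a limit, > 4000 nM. Within the data shown here, the single step between measured compounds that differ in one place is an at least 2.3-fold lower number from compound 2 to compound 3 (0.37 log units; beyond the scatter), an aryl group on the amine nitrogen replacing a small cycloalkyl.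

Compound 4 `O=C1C=C(NC2CCCC2)C(=O)c2c1nc1n2[C@H]2OC[C@@H](O)[C@H]2OC1` differs from compound 1 by cyclopentyl in place of 3,4-dimethylphenyl on an amine nitrogen. This runs the measured step the other way: an aromatic ring on the amine nitrogen is exchanged for a saturated carbocycle, the kind of change that in compound 2 ended at the limit of > 4000 nM in this assay, at which 1 of the 3 values shown sits. A higher number is therefore expected for compound 4, of at least modest size, and the assay may again return only a limit. The expected step is a 4.1-fold higher number from compound 1 to compound 4 (0.61 log units; beyond the scatter). The estimate for compound 4 is 3500 nM, with a range from 1500 nM to 8000 nM.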

Compound 4, half-maximal inhibitory concentration: > 8000 nM
Compound 4 was reported as a limit; the forecaster's own chance of this, stated with the estimate: 40%; middle value at least 2.2-fold (0.35 log units) from the limit.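

The change from 3,4-dimethylphenyl to cyclopentyl on the amine nitrogen gives an at least 9.3-fold higher number from compound 1 to compound 4 (0.96 log units; beyond the scatter) in this assay, so the drop seen with cyclopropyl also appears with a second saturated ring and against a second aromatic partner. Across the four compounds, the two with an aromatic ring on the amine nitrogen, compound 1 and compound 3, return numbers, while the two with a saturated carbocycle there, compound 2 and compound 4, return only limits, and no compound shown goes against this. For compound 4 the reported value is a limit: the limit of > 8000 nM in this assay, at which 1 of the 4 values shown sits.

Compound 2 and compound 4 both stand as limits, so cyclopropyl and cyclopentyl cannot be ordered against each other. Open too, as far as these compounds go, is how a benzyl group, a pyridine ring or a straight butyl chain on the amine nitrogen would read.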